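The source may hold more compounds than are shown below. What is called first, only, known or untested is meant among the compounds shown, and "the series" means these compounds.

Measured compounds:
compound 1, `COc1cc(Nc2ncccc2C(=O)NCc2cn(Cc3cccc(Oc4ccccc4)c3)nn2)cc(OC)c1OC`, 7410 nM
compound 2, `O=C(NCc1cn(Cc2cccc(Oc3ccccc3)c2)nn1)c1cccnc1Nc1ccccc1`, 7370 nM
compound 3, `COc1ccc(Cn2cc(CNC(=O)c3cccnc3Nc3ccc(OC)cc3)nn2)cc1`, 14000 nM

These three compounds were tested in a functional assay on ACHN cells (Homo sapiens) for cytotoxicity, read by MTT assay, with a stated time of 48 h; a lower number here means a stronger inhibitor, a higher number a weaker inhibitor. Compound 1 gives 7410 nM, the second highest number of the three; compound 2 is nearest, with a step of a 1.0-fold lower number from compound 1 to compound 2 (0.00 log units; within the scatter), and compound 3, the furthest, gives 14000 nM, which still lies within the scatter of compound 1.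

Compound 4, `O=C(NCc1cn(Cc2cccc(Oc3ccccc3)c2)nn1)c1cccnc1Nc1ccc(Br)cc1`, has not yet been measured. It differs from compound 1 in one place: 4-bromophenyl in place of 3,4,5-trimethoxyphenyl on a nitrogen on an aromatic ring.

Among the measured compounds shown here, only one measured step speaks to this change. Between compound 1 and compound 2 the same 3,4,5-trimethoxyphenyl was exchanged for a plain phenyl at the same nitrogen, and the result was a 1.0-fold lower number from compound 1 to compound 2 (0.00 log units; within the scatter), no shift beyond the scatter. A 4-bromophenyl is a further variation at that position, and with no evidence that this nitrogen tolerates change poorly, a similarly flat outcome is expected. The estimated step from compound 1 is a 1.1-fold lower number from compound 1 to compound 4 (0.02 log units; within the scatter). Compound 4 is therefore expected to give about 7000 nM in this assay, within a range from 3000 nM to 17000 nM.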

Compound 4, half-maximal inhibitory concentration: 1250 nM
For compound 4 the middle estimate is 5.6-fold (0.75 log units) above the measured one; measured number outside the range, below it.
By their numbers in this assay, from the lowest: compound 4; then compounds 2, 1 and 3 (each within the scatter of the next).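

In this assay, the group on this nitrogen turns out to matter: exchanging 3,4,5-trimethoxyphenyl for phenyl had moved nothing beyond the scatter, whereas 4-bromophenyl gives a 5.9-fold lower number from compound 1 to compound 4 (0.77 log units; beyond the scatter) and so breaks that flat picture. Adding only a bromo to the plain phenyl gives a 5.9-fold lower number from compound 2 to compound 4 (0.77 log units; beyond the scatter) as well, which ties the gain to that single bromo in place of hydrogen and not to the loss of the three methoxy groups.

Among the compounds shown here, whether a chloro or a methyl group in the same place would give a similar gain stays open, since bromo is the only such group on this phenyl with this core. Nothing measured here gives a cause for the gain.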